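Swapping Chlorines for Methyls on a Disulfide-Isomerase Inhibitor

This account rests on a few compounds, and the source may have more. Where it says the series, first, only, none or still open, it means among the compounds named here.

Compound 1 `Cc1ccc(C)c(C(Nc2ccccn2)c2ccc3cccnc3c2O)c1`: 730 nM
Compound 2 `Oc1c(C(Nc2ccccn2)c2c(Cl)cccc2Cl)ccc2cccnc12`: 1890 nM
Compound 3 `Cc1ccnc(NC(c2ccccc2)c2ccc3cccnc3c2O)c1`: < 200 nM

All three share one core and were tested in an assay for inhibition of protein disulfide-isomerase (Homo sapiens), with a stated time of 1 h; on this read-out higher numbers stand for weaker inhibition and lower numbers for stronger inhibition. Compound 3 reports only a limit, < 200 nM, not a number. Of the two numbers given, compound 2 has the higher one, the step of a 2.6-fold higher number from compound 1 to compound 2 (0.41 log units; beyond the scatter) lying beyond the scatter. Compound 4 `Cc1cc(C)c(C(Nc2ccccn2)c2ccc3cccnc3c2O)c(C)c1` awaits measurement; it differs from compound 2 in one place: 2,4,6-trimethylphenyl in place of 2,6-dichlorophenyl on a saturated chain carbon bound to an aromatic carbon and a nitrogen on an aromatic ring. Among the measured compounds shown here, the only measured step bearing on this change is a 2.6-fold higher number from compound 1 to compound 2 (0.41 log units; beyond the scatter), in which two methyl groups gave way to two chlorines and the number rose; the new change runs the other way, bringing methyl groups back. A fall of similar size is therefore expected, the estimated step being a 2.4-fold lower number from compound 2 to compound 4 (0.37 log units; beyond the scatter). For compound 4 the estimated value is 800 nM, within 300 nM to 2200 nM.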

Compound 4, half-maximal inhibitory concentration: 190 nM
Estimate against measurement, compound 4: 4.2-fold (0.62 log units) above; the whole stated range lies above it.
By their numbers in this assay, from the lowest: compound 4; then compound 1; then compound 2.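

In this assay, among the compounds shown here, the group on this saturated chain carbon has a stronger hold on the number than the earlier compounds showed: 2,4,6-trimethylphenyl in place of 2,6-dichlorophenyl gives a 9.9-fold lower number from compound 2 to compound 4 (1.00 log units; beyond the scatter). Methyl groups are also not interchangeable here, since 2,4,6-trimethylphenyl in place of 2,5-dimethylphenyl gives a 3.8-fold lower number from compound 1 to compound 4 (0.58 log units; beyond the scatter).

From the compounds shown here alone, whether methoxy or ethyl groups on this ring would do as well as the methyl groups stays open. Compound 3 cannot be ranked with the others, as its entry is a limit and not a number: the limit of < 200 nM in this assay, at which 1 of the 4 values shown sits.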